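The source may hold more compounds than are shown below. What is called first, only, known or untested is meant among the compounds shown, and "the series" means these compounds.

Compound 1 `CCCCCOc1nc(N)nc2c1ncn2/C=C1/CC1(CO)CO` and compound 2 `Nc1nc2c(ncn2/C=C2/CC2(CO)CO)c(=O)[nH]1` are the two measured compounds.

In an ADME assay on CCRF-HSB-2 cells (Homo sapiens) for cytotoxicity, with a stated time of 7 days (on this read-out higher numbers stand for lower toxicity in this test and lower numbers for higher toxicity in this test), compound 1 gives > 20000 nM, which is a limit of the assay and not a number. Compound 2 also gives only a limit in this assay, > 20000 nM. Both values therefore sit at the limit of > 20000 nM in this assay, at which 2 of the 2 values shown sit, so compound 1 stands at the limit with no number to rank it. Compound 3 `Nc1nc(OCc2ccccc2)c2ncn(/C=C3/CC3(CO)CO)c2n1` differs from compound 1 by phenyl in place of butyl on a saturated chain carbon bound to an oxygen on an aromatic ring. For the measured compounds named here, no measured step informs this change, so no step beyond the scatter is expected in this assay; the estimated step is a step that the limit leaves unreadable from compound 1 to compound 3. Compound 3 is expected to give 25000 nM, within 10000 nM to 60000 nM.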

Compound 3, half-maximal cytotoxic concentration: > 20000 nM
Compound 3 was reported as a limit (the forecaster's own chance of this, stated with the estimate: 80%); the middle value lies beyond the limit too.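

No step can be read from compound 1 to compound 3, as all the values shown are limits: the limit of > 20000 nM in this assay, at which 3 of the 3 values shown sit.

In this assay the compounds shown leave open whether pentyloxy to benzyloxy changes the read-out at all.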